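A Fluoro Substituent Tried on the Anilino Ring

The source may report more compounds than this note shows. Statements on the series, on what has been measured and on what is new or still open speak of the compounds shown alone.

Compound 1 `O=C1C(N2CCCCC2)=CC(=O)c2c1nc1n2[C@H]2OC[C@@H](O)[C@H]2OC1` — in a functional assay on HeLa cells (Homo sapiens) for inhibition, read by sulforhodamine B assay (a higher number here means a weaker inhibitor, a lower number a stronger inhibitor), compound 1 gives > 16000 nM, which is a limit of the assay.
Compound 2 `COc1ccccc1NC1=CC(=O)c2c(nc3n2[C@H]2OC[C@@H](O)[C@H]2OC3)C1=O` — in this assay compound 2 gives 7460 nM.
Compound 3 `O=C1C(Nc2ccccc2)=CC(=O)c2c1nc1n2[C@H]2OC[C@@H](O)[C@H]2OC1` — in this assay compound 3 gives > 8000 nM, which is a limit of the assay.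

Compound 3 therefore stands only as a limit in this assay, and one of the other two values shown is a limit as well, so compound 3 can be placed only as a weak inhibitor, not ranked precisely. Compound 4 `O=C1C(Nc2ccccc2F)=CC(=O)c2c1nc1n2[C@H]2OC[C@@H](O)[C@H]2OC1` differs from compound 3 by fluoro in place of hydrogen on an aromatic carbon. Going by the values given here, no measured step exchanges hydrogen for fluoro on this ring. The nearest comparison is an at least 1.0-fold higher number from compound 2 to compound 3 (0.03 log units; that floor lies within the scatter), in which a group on the same aromatic ring was removed and the floor of the step lies within the scatter. On that basis a small step, a step that the limit leaves unreadable from compound 3 to compound 4, is expected in this assay, with a real chance that the assay again reports only a limit. Compound 4 is estimated at 12000 nM in this assay, within a range from 5000 nM to 30000 nM.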

Compound 4, half-maximal inhibitory concentration: 9820 nM
For compound 4 the middle estimate is 1.2-fold (0.09 log units) above the measured one; the range from low to high includes it.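

In this assay the exchange of methoxy for fluoro gives a 1.3-fold higher number from compound 2 to compound 4 (0.12 log units; within the scatter), so these two groups cannot be told apart on this ring. Against the piperidin-1-yl group of compound 1, the (2-fluorophenyl)amino group gives an at least 1.6-fold lower number from compound 1 to compound 4 (0.21 log units; that floor lies within the scatter), so this step alone does not establish a real gain. Compound 3 stands only at a limit, so its step to compound 4 cannot be read, and the effect of fluoro against hydrogen has no size: the limit of > 8000 nM in this assay, at which 1 of the 4 values shown sits.

On these data alone, it remains open whether a trifluoromethyl group, an amine or a carboxylic acid on this ring would move the number beyond the scatter. As far as these compounds go, it also remains open whether fluoro elsewhere on the same ring would read differently from compound 4.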